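Tetrazole for carboxylic acid on the acid chain

The compounds below may be only part of what the source reports. "The series", "measured", "known", "first", "only" and "open" are said of these compounds alone.

Compound 1 `O=C(O)CCC(Cc1ccc(OCc2ccc3ccccc3n2)cc1)c1ccccc1` is the reference point. Among the measured compounds shown here, in an assay on membranes from lung (Cavia porcellus) for binding affinity to cysteinyl leukotriene receptor (Homo sapiens) (a higher number here means a weaker inhibitor, a lower number a stronger inhibitor), compound 1 gives 31 nM, the lowest of the two numbers so far. Its nearest neighbour is compound 2 `CC(CCC(=O)O)Cc1ccc(OCc2ccc3ccccc3n2)cc1`, which in this assay gives 43 nM; the step of a 1.4-fold higher number from compound 1 to compound 2 (0.14 log units; within the scatter) changes only the group on the branching carbon and is within the scatter. Compound 3 `c1ccc(C(CCc2nnn[nH]2)Cc2ccc(OCc3ccc4ccccc4n3)cc2)cc1` differs from compound 1 by 1H-tetrazol-5-yl in place of carboxy on a saturated chain carbon, three bonds along the chain from an aromatic carbon. For the measured compounds named here, no measured step touches this end of the chain, so nothing bears directly on the change; the expectation rests on the value of compound 1 alone. For compound 3 the expected outcome is a step of a 1.6-fold lower number from compound 1 to compound 3 (0.19 log units; within the scatter), that is, no shift beyond the scatter. Compound 3 is accordingly estimated at 20 nM in this assay, with a range from 5 nM to 80 nM.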

Compound 3, inhibition constant: 8 nM
Compound 3: the middle estimate sits 2.5-fold (0.40 log units) above what was measured; the range from low to high includes it.
By their numbers in this assay, from the lowest: compound 3; then compounds 1 and 2 (each within the scatter of the next).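

In this assay, among the compounds shown here, this end of the chain shows a change beyond the scatter, which the only earlier step, a 1.4-fold higher number from compound 1 to compound 2 (0.14 log units; within the scatter), did not. Putting 1H-tetrazol-5-yl in place of carboxy at this place gives a 3.9-fold lower number from compound 1 to compound 3 (0.59 log units; beyond the scatter), a modest step, so with the phenyl-bearing chain of compound 1 the carboxy group can be replaced without loss in this assay. Nothing at hand accounts for the lower number with 1H-tetrazol-5-yl.

On these data alone, it remains open whether the same replacement gives a similar step with methyl in place of phenyl on the chain. Also open, as far as these compounds go, is how a hydroxamic acid, an acyl sulfonamide or a primary amide at this place would read, and whether a longer chain carrying 1H-tetrazol-5-yl keeps the lower number.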